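Benzyl change from compound 3 to compound 4

This account rests on a few compounds, and the source may have more. Where it says the series, first, only, none or still open, it means among the compounds named here.

Values in a functional assay on MGC-803 cells (Homo sapiens) for inhibition, read by CCK-8 assay, with a stated time of 48 h (a higher number here means a weaker inhibitor, a lower number a stronger inhibitor), so far:
compound 1 `COc1ccc(CN(C(=O)CSC(=S)N2CCc3ccccc32)c2cc(OC)c(OC)c(OC)c2)cc1` gives 8410 nM 
compound 2 `CCN1CCN(CC(=O)N(Cc2ccc(OC)cc2)c2cc(OC)c(OC)c(OC)c2)CC1` gives > 20000 nM as a limit of the assay
compound 3 `COc1cc(N(Cc2ccc(Br)cc2)C(=O)CSC(=S)N2CCN(C(=O)OC(C)(C)C)CC2)cc(OC)c1OC` gives 12400 nM 

In this assay compound 3 at 12400 nM and compound 1 at 8410 nM sit within the scatter of each other. Going from compound 3 to compound 4 `COc1ccc(CN(C(=O)CSC(=S)N2CCN(C(=O)OC(C)(C)C)CC2)c2cc(OC)c(OC)c(OC)c2)cc1C` the change is 4-methoxy-3-methylphenyl in place of 4-bromophenyl on a saturated chain carbon bound to an amide-type nitrogen and reads as 4-bromobenzyl to 4-methoxy-3-methylbenzyl. Among the compounds with values here, the one measured step of an at least 2.3-fold higher number from compound 1 to compound 2 (0.37 log units; beyond the scatter) sits at another place, on a saturated chain carbon bound to a carbonyl carbon, and gives no size for this change. Within the data shown here, no measured step isolates this swap, so no shift beyond the scatter is expected. The expected shift is a 1.2-fold lower number from compound 3 to compound 4 (0.09 log units; within the scatter) in this assay and should stay within the scatter. For compound 4 the estimated value is 10000 nM within an expected range of 4500 nM to 20000 nM for this measurement.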

Compound 4, half-maximal inhibitory concentration: > 20000 nM
Compound 4 was reported as a limit; the forecaster's own chance of this, stated with the estimate: 15%; middle value at least 2.0-fold (0.30 log units) away from the limit.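

This pair is the only one shown that changes the group on a saturated chain carbon bound to an amide-type nitrogen: in this assay, 4-bromobenzyl to 4-methoxy-3-methylbenzyl gives an at least 1.6-fold higher number from compound 3 to compound 4 (0.20 log units; that floor lies within the scatter). No loss beyond the scatter is established, and the swap gives no gain. The size of the step stays unread because the value of compound 4 is a limit: the limit of > 20000 nM in this assay, at which 2 of the 4 values shown sit.

Compound 3 and compound 4 alone do not separate the methoxy from the methyl of the entering group. As far as these compounds go, how a benzyl carrying an amine or a carboxylic acid would read at this place remains open.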